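A New Group on an Amide-Type Nitrogen

This account rests on a few compounds, and the source may have more. Where it says the series, first, only, none or still open, it means among the compounds named here.

Measured so far in a functional assay on A549 cells (Homo sapiens) for antiproliferative activity, read by MTT assay; on this read-out higher numbers stand for weaker inhibition and lower numbers for stronger inhibition
Compound 1 `COc1cc2c(Oc3ccc(NC(=O)Nc4cccc(C)c4)cc3)ccnc2cc1OCCCCCCC(=O)NO` gives 2010 nM
Compound 2 `COc1cc2c(Oc3ccc(NC(=O)N/N=C/c4ccc(F)cc4)cc3)ccnc2cc1OCCCCCCC(=O)NO` gives 4920 nM

Of these two numbers, compound 2 stands higher at 4920 nM, making it the weaker inhibitor of the pair. Compound 3 `COc1cc2c(Oc3ccc(NC(=O)NNC(=O)c4cccc(C)c4)cc3)ccnc2cc1OCCCCCCC(=O)NO` has not yet been measured. Its structure departs from that of compound 2 as follows: a group of 10 heavy atoms (8 carbon, 1 nitrogen, 1 oxygen; one six-membered aromatic ring of carbon only) in place of a group of 9 heavy atoms (7 carbon, 1 nitrogen, 1 fluorine; one six-membered aromatic ring of carbon only), on an amide-type nitrogen. The change sits on an amide-type nitrogen whose other neighbours are: carbonyl carbon, and the entering ((3-methylphenyl)carbonyl)amino group keeps one six-membered aromatic ring of carbon only.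

Just one measured step bears on this place: a 2.4-fold higher number from compound 1 to compound 2 (0.39 log units; beyond the scatter). That step is modest, and a single step gives only a thin basis for prediction. Compound 1, at 2010 nM, is the only other reference point, so a small move toward a lower number is expected in this assay, probably no larger than that modest step and possibly within the scatter. The estimated change is a 1.5-fold lower number from compound 2 to compound 3 (0.19 log units; within the scatter). For compound 3 the expected value is 3200 nM, with an estimated range from 1200 nM to 8000 nM.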

Compound 3, half-maximal inhibitory concentration: 8190 nM
For compound 3 the middle estimate is 2.6-fold (0.41 log units) below the measured one; measured number outside the range, above it.
By their numbers in this assay, from the lowest: compound 1; then compounds 2 and 3 (each within the scatter of the next).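

In this assay, the ((3-methylphenyl)carbonyl)amino group of compound 3 gives a 1.7-fold higher number from compound 2 to compound 3 (0.22 log units; within the scatter), so at this amide-type nitrogen it cannot be told apart from the group it replaces in compound 2. Measured against 3-methylphenyl, the same entering group gives a 4.1-fold higher number from compound 1 to compound 3 (0.61 log units; beyond the scatter), a step beyond the scatter, which shows that keeping a 3-methylphenyl ring in the new group does not by itself preserve the number of compound 1. Compound 2 and compound 3 thus both stand apart from compound 1 on the side of weaker inhibition, and neither goes against this among the three compounds shown, although both replacement groups carry a nitrogen on this amide-type nitrogen and differ in their other atoms.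

Going by these compounds, what remains open is whether a 4-fluorophenyl group placed directly on this amide-type nitrogen, or a simple amino group, would give a number closer to that of compound 1 or closer to those of compound 2 and compound 3. Nothing available here accounts for the gap between 3-methylphenyl and the two longer groups.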